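The compounds below may be only part of what the source reports. "The series", "measured", "known", "first", "only" and "open" are said of these compounds alone.

Measured so far:
compound 1 `CSc1ccc(OCc2ccc(F)cc2)c(C2=C(c3cccc(C(=O)O)c3)CCC2)c1`: 31.6 nM
compound 2 `CSc1ccc(OCc2ccccc2)c(C2=C(c3cccc(C(=O)O)c3)CCC2)c1`: 63.1 nM
compound 3 `CS(=O)(=O)c1ccc(OCc2ccc(F)cc2)c(C2=C(c3cccc(C(=O)O)c3)CCC2)c1`: 79.4 nM

All three were read in an assay on isolated protein for inhibition of prostaglandin E2 receptor EP1 subtype (Homo sapiens); on this read-out lower numbers stand for stronger inhibition and higher numbers for weaker inhibition. The change fluoro in place of hydrogen on an aromatic carbon gave a 2.0-fold lower number from compound 2 to compound 1 (0.30 log units; within the scatter). The further change to compound 3 gave a 2.5-fold higher number from compound 1 to compound 3 (0.40 log units; beyond the scatter), so compound 3 stands at the highest number of the three. The difference between the cores of compound 2 and compound 3 is not broken down here.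

Compound 4 `CS(=O)(=O)c1ccc(OCc2ccc(F)cc2F)c(C2=C(c3cccc(C(=O)O)c3)CCC2)c1` is not yet measured. It differs from compound 3 by fluoro in place of hydrogen on an aromatic carbon, the same kind of change as fluoro in place of hydrogen on an aromatic carbon, but at a different place: in compound 4 the fluoro enters ortho to a large group and meta to a fluoro group, whereas in compound 1 it entered para to a large group.

For compound 4 the expected step is a 1.6-fold lower number from compound 3 to compound 4 (0.20 log units; within the scatter), because the same kind of change gave a 2.0-fold lower number from compound 2 to compound 1 (0.30 log units; within the scatter) earlier. On that basis compound 4 is estimated at 50 nM, with a range from 20 nM to 150 nM.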

Compound 4, half-maximal inhibitory concentration: 15.9 nM
Estimate against measurement, compound 4: 3.1-fold (0.50 log units) above, and the stated range ends above it.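

In this assay the change from 4-fluorobenzyl to 2,4-difluorobenzyl gives a 5.0-fold lower number from compound 3 to compound 4 (0.70 log units; beyond the scatter) and does not separate from the earlier fluoro step on the other core: the same change on two cores in this assay, a 2.0-fold lower number (0.30 log units; within the scatter) from compound 2 to compound 1 and a 5.0-fold lower number (0.70 log units; beyond the scatter) from compound 3 to compound 4, 2.5-fold (0.40 log units) apart, within the scatter of two such steps. The pair therefore shows no difference between the two cores beyond the scatter. It does not show that the step holds on further cores, and the fluoro enters at a different place in each step, so place and core are not told apart.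

Still open, as far as these compounds go, is how 2,4-difluorobenzyl reads on the core of compound 1, which would compare the two cores at one place. Also open, from the compounds shown here alone, is whether chloro or methyl at this place reads like fluoro, and whether an amide can stand in place of the carboxylic acid.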